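Side-chain variation at the benzylic carbon of the shared core

This account rests on a few compounds, and the source may have more. Where it says the series, first, only, none or still open, it means among the compounds named here.

Measured so far:
compound 1 `CC(C)NC(=O)CC(c1ccc(-c2ccc3cccc(F)c3c2)[nH]c1=O)C(C)C` — 5.8 nM
compound 2 `CC(C)C(c1ccc(-c2ccc3cccc(F)c3c2)[nH]c1=O)N1CCNC1=O` — 9.1 nM
compound 3 `CC(C)C(Nc1nnc[nH]1)c1ccc(-c2ccc3cccc(F)c3c2)[nH]c1=O` — 22 nM

All three compounds share the same core and differ only in the group carried on a saturated chain carbon bound to an aromatic carbon and a saturated chain carbon. In an assay on CHO cells for displacement of a labelled ligand from prostaglandin E2 receptor EP3 subtype (Homo sapiens), read by radioligand binding (a higher number here means a weaker inhibitor, a lower number a stronger inhibitor), compound 1 gives 5.8 nM, the lowest number of the three. The step of a 1.6-fold higher number from compound 1 to compound 2 (0.20 log units; within the scatter) shows that the cyclic urea is tolerated, while a 3.8-fold higher number from compound 1 to compound 3 (0.58 log units; beyond the scatter) and a 2.4-fold higher number from compound 2 to compound 3 (0.38 log units; beyond the scatter) show a modest loss when a five-membered aromatic ring is attached through an amino link.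

Compound 4 `Cc1c[nH]c(C(c2ccc(-c3ccc4cccc(F)c4c3)[nH]c2=O)C(C)C)n1` has not yet been measured. It differs from compound 1 by 4-methyl-1H-imidazol-2-yl in place of (isopropylcarbamoyl)methyl on a saturated chain carbon bound to an aromatic carbon and a saturated chain carbon. Within the data shown here, the nearest precedent is compound 3, whose step a 3.8-fold higher number from compound 1 to compound 3 (0.58 log units; beyond the scatter) carries a five-membered aromatic ring in the same place, though through an extra linker atom; compound 4 attaches the ring directly, as compound 2 does its ring. A modest weakening, between the outcomes of compound 2 and compound 3, is therefore expected, giving a step of a 2.6-fold higher number from compound 1 to compound 4 (0.41 log units; beyond the scatter). For compound 4 the value in this assay is estimated at 15 nM, with a range from 6 nM to 40 nM.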

Compound 4, inhibition constant: 12 nM
Compound 4: middle estimate off by 1.3-fold (0.10 log units), on the high side, and the stated range covers the measured number.
By their numbers in this assay, from the lowest: compounds 1, 2, 4 and 3 (each within the scatter of the next, the first and the last beyond it).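

With a 1.3-fold higher number from compound 2 to compound 4 (0.12 log units; within the scatter) and a 1.8-fold lower number from compound 3 to compound 4 (0.26 log units; within the scatter) in this assay, the 4-methyl-1H-imidazol-2-yl group, a five-membered aromatic ring on the saturated chain carbon, cannot be told apart from the 2-oxoimidazolidin-1-yl group or the (4H-1,2,4-triazol-3-yl)amino group. Set against the (isopropylcarbamoyl)methyl group, the change gives a 2.1-fold higher number from compound 1 to compound 4 (0.32 log units; beyond the scatter), a modest loss that is beyond the scatter, though the entering group has no carbonyl and no open chain. No measurement at hand accounts for the differences among these groups.

The compounds shown leave open whether the methyl on the imidazole ring matters, which an unsubstituted imidazole would test. They also leave open what a primary amine or a carboxylic acid would give on the same carbon.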